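The source may report more compounds than this note shows. Statements on the series, on what has been measured and on what is new or still open speak of the compounds shown alone.

Compound 3 `OC[C@H]1O[C@@H](n2cnc3c(CSc4cccc(Cl)c4)ncnc32)[C@H](O)[C@@H]1O` gives the lowest number of the three measured in an assay on isolated protein for binding affinity to Equilibrative nucleoside transporter 1 (Homo sapiens) (a higher number here means a weaker inhibitor, a lower number a stronger inhibitor), at 282 nM. Compound 2 `OC[C@H]1O[C@@H](n2cnc3c(CSc4cccc(Br)c4)ncnc32)[C@H](O)[C@@H]1O` gives 363 nM, a result that lies within the usual scatter of compound 3, so the two cannot be ranked against each other. Compound 1 `OC[C@H]1O[C@@H](n2cnc3c(CSc4c(F)cccc4Cl)ncnc32)[C@H](O)[C@@H]1O` gives 1510 nM; the difference a 5.4-fold lower number from compound 1 to compound 3 (0.73 log units; beyond the scatter) lies beyond the scatter, as does a 4.2-fold lower number from compound 1 to compound 2 (0.62 log units; beyond the scatter). Compound 4 `OC[C@H]1O[C@@H](n2cnc3c(CSc4cccc(I)c4)ncnc32)[C@H](O)[C@@H]1O` differs from compound 3 by a single change: iodo in place of chloro on an aromatic carbon. Among the compounds with values here, the one measured step that bears on a halogen swap at this place is a 1.3-fold lower number from compound 2 to compound 3 (0.11 log units; within the scatter), a change that stayed within the scatter. On that basis, putting iodo where chloro was is expected to leave the number roughly where compound 3 stands, and the step of a 1.1-fold lower number from compound 3 to compound 4 (0.05 log units; within the scatter) is estimated to be small. Compound 4 is therefore expected to give about 250 nM, with a likely range from 100 nM to 650 nM.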

Compound 4, half-maximal inhibitory concentration: 245 nM
For compound 4 the middle estimate is 1.0-fold (0.01 log units) above the measured one; low and high end bracket the measured number.
By their numbers in this assay, from the lowest: compounds 4, 3 and 2 (each within the scatter of the next); then compound 1.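

Iodo now joins chloro and bromo on this aromatic carbon, and the halogens cannot be ranked in this assay: the step of a 1.2-fold lower number from compound 3 to compound 4 (0.06 log units; within the scatter) and the step of a 1.5-fold lower number from compound 2 to compound 4 (0.17 log units; within the scatter) both stay within the scatter, so swapping among these three halogens here has shown no measurable effect. The step of a 6.2-fold lower number from compound 1 to compound 4 (0.79 log units; beyond the scatter) lies beyond the scatter, which places 3-iodophenyl with 3-chlorophenyl and 3-bromophenyl on the same side of the gap from 2-chloro-6-fluorophenyl. Nothing at hand explains why these three halogens read alike. Going by these compounds, whether a methoxy group, an amine or a carboxylic acid on this same aromatic carbon would keep the number in this range remains open. So does the effect of a single chlorine on the ring carbon nearest the sulfur, apart from the fluorine that compound 1 also carries.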